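The source may hold more compounds than are shown below. What is called first, only, known or untested is meant among the compounds shown, and "the series" means these compounds.

Measured compounds in a functional assay on CNE-2 cells (Homo sapiens) for cytotoxicity, read by MTT assay, with a stated time of 72 h; on this read-out lower numbers stand for stronger inhibition and higher numbers for weaker inhibition:
- compound 1 `O=C(NC(=S)NNc1ncnc2ccccc12)c1ccc(F)cc1`: 2840 nM
- compound 2 `O=C(NC(=S)NNc1ncnc2ccccc12)c1ccc(Cl)cc1`: 1530 nM
- compound 3 `O=C(NC(=S)NNc1ncnc2ccccc12)c1cccc(Cl)c1`: 2920 nM

Compound 3 gives the highest of the three numbers in this assay, but its nearest neighbour is compound 1 at a 1.0-fold higher number from compound 1 to compound 3 (0.01 log units; within the scatter) and the furthest is compound 2 at a 1.9-fold higher number from compound 2 to compound 3 (0.28 log units; within the scatter), so all three sit within the scatter of one another and no order among them can be read.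

Compound 4 `Cc1ccccc1C(=O)NC(=S)NNc1ncnc2ccccc12` differs from compound 3 by 2-methylphenyl in place of 3-chlorophenyl on a carbonyl carbon. The measured steps that bear on this are all changes of the same aryl group on the carbonyl carbon: a 1.9-fold lower number from compound 1 to compound 2 (0.27 log units; within the scatter) and a 1.9-fold higher number from compound 2 to compound 3 (0.28 log units; within the scatter), together with a 1.0-fold higher number from compound 1 to compound 3 (0.01 log units; within the scatter). Among the measured compounds shown here, none of them leaves the scatter, and no step with a methyl group or with a 2-substituted phenyl has been measured, so the expectation rests on the general insensitivity of this assay to this part of the molecule.

The expected step is therefore a 1.0-fold higher number from compound 3 to compound 4 (0.01 log units; within the scatter), that is, none beyond the scatter. For compound 4 the estimate in this assay is 3000 nM, with a range of 1200 nM to 7500 nM.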

Compound 4, half-maximal inhibitory concentration: 5460 nM
Beside the measured number, compound 4's estimate is 1.8-fold (0.26 log units) below it; measured number inside the range.
By their numbers in this assay, from the lowest: compounds 2, 1, 3 and 4 (each within the scatter of the next, the first and the last beyond it).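

In this assay, the aryl group on the carbonyl carbon now yields its first step beyond the scatter, though a modest one: a 3.6-fold higher number from compound 2 to compound 4 (0.55 log units; beyond the scatter), with 2-methylphenyl in place of 4-chlorophenyl. The same 2-methylphenyl group stays within the scatter against the other two aryl groups, at a 1.9-fold higher number from compound 3 to compound 4 (0.27 log units; within the scatter) and a 1.9-fold higher number from compound 1 to compound 4 (0.28 log units; within the scatter), so this position is not fully insensitive to change, but only compound 2 and compound 4 are separated, while compound 1 and compound 3 remain within the scatter of both. No data at hand account for the gap between compound 2 and compound 4.

The step from compound 2 to compound 4 changes both the substituent and the ring position named in the group, so the compounds shown leave open which of the two carries it. Also open, as far as these compounds go, is how this position responds to a phenyl group bearing an amine or a carboxylic acid, or to a longer chain in place of the aryl group.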